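Sulfoxide amides on a dichloro-styrylnitrile core: tolerance in cells

The source may hold more compounds than are shown below. What is called first, only, known or untested is meant among the compounds shown, and "the series" means these compounds.

Of the compounds shown here, two sharing one core have been tested in an ADME assay on MT4 cells (Homo sapiens) for cytotoxicity, read by MTT assay, with a stated time of 5 days; a lower number here means that less compound is tolerated, a higher number that more compound is tolerated. Compound 1 `COc1cc2nc(SCC(=O)Nc3ccc(Cl)cc3)nc(Nc3c(Cl)cc(/C=C/C#N)cc3Cl)c2cc1OC` carries a sulfide and a 4-chlorophenyl amide; in this assay compound 1 gives 29500 nM. Compound 2 `COc1cc2nc([S+]([O-])CC(=O)Nc3ccccc3C(F)(F)F)nc(Nc3c(Cl)cc(/C=C/C#N)cc3Cl)c2cc1OC` carries a sulfoxide and a 2-(trifluoromethyl)phenyl amide. For compound 2 this assay reports only a limit, > 192000 nM, so compound 2 stands at the upper edge of the numbers shown, as noted in the limit of > 192000 nM in this assay, at which 1 of the 2 values shown sits. Compound 3 `COc1cc2nc([S+]([O-])CC(=O)Nc3c(C)cc(C)cc3C)nc(Nc3c(Cl)cc(/C=C/C#N)cc3Cl)c2cc1OC` keeps the sulfoxide and changes the amide ring: 2,4,6-trimethylphenyl in place of 2-(trifluoromethyl)phenyl on an amide-type nitrogen. Since compound 2 sits at the limit, no step beyond the scatter is expected; the most likely outcome is another limit. Compound 3 is therefore expected to give about 150000 nM, between 60000 nM and 400000 nM. This estimate means a step of an at least 1.2-fold lower number from compound 2 to compound 3 (0.10 log units; that floor lies within the scatter), expected to fall within the scatter.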

Compound 3, half-maximal cytotoxic concentration: 8870 nM
Compound 3: middle estimate off by 17-fold (1.23 log units), on the high side; the whole stated range lies above it.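

With the sulfoxide held fixed, the amide ring alone moves the reading in this assay: 2,4,6-trimethylphenyl in place of 2-(trifluoromethyl)phenyl on the amide nitrogen gives an at least 21-fold lower number from compound 2 to compound 3 (1.33 log units; beyond the scatter). Keeping the sulfoxide is therefore not enough to place a compound at the limit, as compound 3 keeps it and still gives a measured number. Compound 2 stands at a limit and not at a number, so this step is a floor and its full size cannot be read: the limit of > 192000 nM in this assay, at which 1 of the 3 values shown sits.

The compounds shown leave open whether the change follows the loss of the trifluoromethyl group or the arrival of the methyl groups, and a plain phenyl ring or a 2-methylphenyl ring would separate the two. They also leave open how the sulfide and the sulfoxide compare on one and the same amide ring, and how an amine or a carboxylic acid on that ring would read.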